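Anilide series: methoxy to hydrogen, compound 3 to compound 4

The source may report more compounds than this note shows. Statements on the series, on what has been measured and on what is new or still open speak of the compounds shown alone.

Measured so far, read in a functional assay on NUGC-3 cells (Homo sapiens) for cytotoxicity, read by sulforhodamine B assay, with a stated time of 72 h; a lower number here means a stronger inhibitor of growth, a higher number a weaker inhibitor of growth:
compound 1 `O=C(Nc1ccccc1C(F)(F)F)C1CCc2ccccc2N1C(=O)c1ccccc1`, 8120 nM
compound 2 `CCCCCCCCC(=O)N1c2ccccc2CCC1C(=O)Nc1ccccc1C(F)(F)F`, 6180 nM
compound 3 `COc1ccc(NC(=O)C2CCc3ccccc3N2)cc1`, 51900 nM

Compound 3 gives the highest number of the three in this assay: compared with compound 1 it sits at a gap beyond the scatter, and compared with compound 2 at a somewhat wider gap, also beyond the scatter. Compound 3 is thus the weakest inhibitor of growth among the measured compounds.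

Compound 4 `O=C(Nc1ccccc1)C1CCc2ccccc2N1` differs from compound 3 in one place: hydrogen in place of methoxy on an aromatic carbon.

Among the compounds with values here, the only measured step, a 1.3-fold lower number from compound 1 to compound 2 (0.12 log units; within the scatter), lies on the carbonyl attached to the ring nitrogen and is within the scatter; it concerns a different part of the molecule and does not speak to the anilide ring. Compounds 1 and 2 also carry a trifluoromethyl group that compound 3 and compound 4 lack, so their numbers give no direct read on the anilide substituent either. Within the data shown here, no measured pair isolates the methoxy-to-hydrogen change, so the expectation defaults to no step beyond the scatter, with wide uncertainty in both directions.

For compound 4 the expected step is a 1.0-fold higher number from compound 3 to compound 4 (0.00 log units; within the scatter), with no direction preferred. Compound 4 is therefore estimated at 52000 nM, within a range of 22000 nM to 125000 nM.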

Compound 4, concentration for 50% growth inhibition: 59000 nM
For compound 4 the middle estimate is 1.1-fold (0.05 log units) below the measured one; the measured number falls inside the stated range.
By their numbers in this assay, from the lowest: compounds 2 and 1 (each within the scatter of the next); then compounds 3 and 4 (each within the scatter of the next).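

In this assay, within the data shown here, the step of a 1.1-fold higher number from compound 3 to compound 4 (0.06 log units; within the scatter) is the first read on the anilide ring, and it lies within the scatter. At this position, on an aromatic carbon para to a large group, methoxy and hydrogen cannot be told apart, so the methoxy, with its 2 heavy atoms and its hydrogen-bond acceptor, is not required for the level of growth inhibition that compound 3 shows. No measurement at hand bears on why the two compounds read alike.

On these data alone, this one pair covers only methoxy and hydrogen at this position, so it remains open whether a larger or differently built group there, such as an amine, a carboxylic acid or a longer alkoxy chain, would give a step beyond the scatter. Among these compounds, also open is how the trifluoromethyl group and the acyl groups on the ring nitrogen of compound 1 and compound 2 each contribute, as those compounds differ from compound 3 and compound 4 in more than one place and no single-change pair links the two sets.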